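A few compounds are considered here, and "the series" means these few. Any claim that something is new, unique, unknown or untested is made for them only; others in the source may bear on it.

Measured in a functional assay on UACC-257 cells (Homo sapiens) for cytotoxicity, read by sulforhodamine B assay, with a stated time of 48 h (a higher number here means that more compound is tolerated, a lower number that less compound is tolerated), so far:
compound 1 `ClCc1cccc(Cn2cnc3c(Cl)ncnc32)c1` gives 67600 nM;
compound 2 `ClCc1ccc(Cn2cnc3nc(Cl)nc(Cl)c32)cc1` gives 34700 nM;
compound 3 `ClCc1cccc(Cn2cnc3c(Cl)nc(Cl)nc32)c1` gives 6450 nM.

Compound 2 stands second highest of the three numbers; its gap to compound 1 lies within the scatter, while its gap to compound 3 lies beyond it. Compound 4 `ClCc1ccc(Cn2cnc3ncnc(Cl)c32)cc1` differs from compound 2 by hydrogen in place of chloro on an aromatic carbon. For the measured compounds named here, the one measured step that bears on this is the reverse change, a 10-fold lower number from compound 1 to compound 3 (1.02 log units; beyond the scatter). Read backwards, removing the chloro would be expected to raise the number in this assay by a comparable amount. Compound 4 is therefore estimated at 150000 nM (range 50000 nM to 400000 nM), an expected step of a 4.3-fold higher number from compound 2 to compound 4 (0.64 log units; beyond the scatter).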

Compound 4, concentration lethal to 50% of the cells: 7760 nM
The estimate for compound 4 lay 19-fold (1.29 log units) above the measured number, and the stated range ends above it.
By their numbers in this assay, from the lowest: compounds 3 and 4 (each within the scatter of the next); then compounds 2 and 1 (each within the scatter of the next).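

In this assay, replacing the chloro between two ring nitrogen atoms with hydrogen gives a 4.5-fold lower number from compound 2 to compound 4 (0.65 log units; beyond the scatter), so on this core the chloro goes with the higher number. The earlier step had shown the opposite, and the effect of this change therefore depends on the core, with its direction reversed: the same change on two cores in this assay, a 10-fold lower number (1.02 log units; beyond the scatter) from compound 1 to compound 3 and a 4.5-fold higher number (0.65 log units; beyond the scatter) from compound 4 to compound 2, 47-fold (1.67 log units) apart, beyond the scatter of two such steps.

The compounds shown leave open how an amine or a methoxy group would fare at this position. They also do not separate which of the differences between the two cores sets the direction of the change.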